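This account rests on a few compounds, and the source may have more. Where it says the series, first, only, none or still open, it means among the compounds named here.

Measured so far:
Compound 1 `CCOC(=O)CCCCCOc1cccc(CN(C(=O)c2ccc(-c3cccc(Oc4ccccc4)c3)cc2)C(C)C)c1` gives > 19600 nM in an ADME assay on BJ cells (Homo sapiens) for cytotoxicity, read by CellTiter-Glo and resazurin assay, with a stated time of 72 h (on this read-out lower numbers stand for an effect already at smaller amounts and higher numbers for an effect only at larger amounts of compound), a limit of the assay rather than a number.
Compound 2 `CCOC(=O)CCCCCOc1cccc(CN(C(=O)c2ccc(-c3cccc(OC)c3)cc2)C(C)C)c1` gives > 21000 nM in this assay, again only a limit.

Going by the values given here, compound 2 therefore stands at the limit, and the one further value shown is a limit as well, so neither compound reached a measurable effect in this assay. Among the compounds with values here, the one step between them, a step that the two limits leave unreadable from compound 1 to compound 2, cannot be read because the limit of > 19600 nM in this assay, at which 1 of the 2 values shown sits, and the limit of > 21000 nM in this assay, at which 1 of the 2 values shown sits, leave no number to compare.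

Compound 3 `CCOC(=O)CCCCCOc1cccc(CN(C(=O)c2ccc(Br)cc2)C(C)C)c1` differs from compound 2 by bromo in place of 3-methoxyphenyl on an aromatic carbon. Within the data shown here, no measured step bears on this change with a readable size, so nothing in the data points to a step beyond the usual scatter in this assay, in either direction.

Compound 3 is therefore expected to sit near compound 2, at about 20000 nM, with a likely range from 6000 nM to 40000 nM, which means an expected step of an at least 1.0-fold lower number from compound 2 to compound 3 (0.02 log units; that floor lies within the scatter).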

Compound 3, half-maximal effective concentration: > 26000 nM
Compound 3: only a limit was reported; the forecaster's own chance of this, stated with the estimate: 70%; middle value at least 1.3-fold (0.11 log units) away from the limit.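

Compound 2 and compound 3 are both reported only as limits in this assay, and the step between them cannot be read. The compounds shown leave open at what concentration, if any, compound 1, compound 2 or compound 3 would give a measurable effect in this assay.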